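Moving the acid round the ring: compound 3 to compound 4

This account rests on a few compounds, and the source may have more. Where it says the series, first, only, none or still open, it means among the compounds named here.

A small set of compounds built on a shared core was examined in an assay on HEK293 cells for positive allosteric modulation of metabotropic glutamate receptor 3 (Rattus norvegicus), read by thallium flux, with a stated time of 2.5 min; a lower number here means that less compound is needed, a higher number that more compound is needed for the effect. Compound 1, with the structure `Cc1c(OCCCCOc2ccc(C(=O)O)cc2Cl)ccc(C(=O)CC2CCCC2)c1O`, gives only a limit in this assay, namely > 10000 nM. Compound 2, with the structure `Cc1c(OCCCCOc2ccccc2C(=O)O)ccc(C(=O)CC2CCCC2)c1O`, has no result in this assay, recorded as "not determined" (no result reported). Compound 3, with the structure `COC(=O)c1ccc(OCCCCOc2ccc(C(=O)CC3CCCC3)c(O)c2C)cc1`, likewise has no result in this assay, recorded as "not determined" (no result reported). So compound 3 stands without a number of its own; beside it sit one limit, that of compound 1 at the limit of > 10000 nM in this assay, at which 1 of the 3 values shown sits, and one empty entry.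

Compound 4, with the structure `Cc1c(OCCCCOc2cccc(C(=O)O)c2)ccc(C(=O)CC2CCCC2)c1O`, has not yet been measured. It differs from compound 3 in one place: 3-carboxyphenyl in place of 4-(methoxycarbonyl)phenyl on an oxygen on a saturated carbon. Among the compounds with values here, since no step between measured compounds is available, no size can be read from the data for this change; the expectation is that compound 4 will at most differ modestly from the limit seen for compound 1, with weak activity the more likely outcome. For compound 4 in this assay the estimate is 15000 nM, with a range from 3000 nM to 60000 nM.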

Compound 4, half-maximal effective concentration: 3400 nM
Compound 4: the middle estimate sits 4.4-fold (0.64 log units) above what was measured, within the range that was stated.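

Compound 4 is the only compound shown with a single number rather than a limit or an empty entry, so the shared core can give a measurable effect in this assay when 3-carboxyphenyl sits on this oxygen. Putting that group in place of 4-carboxy-2-chlorophenyl gives an at least 2.9-fold lower number from compound 1 to compound 4 (0.46 log units; beyond the scatter), but the swap both moves the acid and removes the chlorine, so neither change alone can be credited with the step. Compound 1 gives only a limit, so the full size of this step is unknown: the limit of > 10000 nM in this assay, at which 1 of the 4 values shown sits.

Steps involving compound 2 or compound 3 cannot be read, so neither the other acid placements nor the methyl ester can be compared with compound 4. On these data alone, it also remains open how a tetrazole or a primary amide in place of the carboxylic acid would fare at this position.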